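Working notes: bromo to methyl exchange

The source may report more compounds than this note shows. Statements on the series, on what has been measured and on what is new or still open speak of the compounds shown alone.

- compound 1 `Cc1ccc(C(=O)N2CCN(CC(=O)N3CCN(CCCc4c[nH]c5ccccc45)CC3)CC2)cc1` gives 159000 nM
- compound 2 `COc1ccc2[nH]cc(CCCN3CCN(C(=O)CN4CCN(C(=O)c5ccc(Br)cc5)CC4)CC3)c2c1` gives 80500 nM

In an ADME assay on HEK293 cells (Homo sapiens) for cytotoxicity, read by MTT assay, with a stated time of 72 h (on this read-out higher numbers stand for weaker inhibition and lower numbers for stronger inhibition), compound 2 stands at 80500 nM, within the scatter of compound 1 at 159000 nM, so the two numbers count as one level. Compound 3 `COc1ccc2[nH]cc(CCCN3CCN(C(=O)CN4CCN(C(=O)c5ccc(C)cc5)CC4)CC3)c2c1` shares the core of compound 2 and differs by methyl in place of bromo on an aromatic carbon, with methyl in place of bromo on an aromatic carbon. Among the measured compounds shown here, no measured step covers this exchange, so no change beyond the scatter is expected in this assay. The expected size of the change is a 1.2-fold higher number from compound 2 to compound 3 (0.09 log units; within the scatter). The estimate for compound 3 is 100000 nM, with an expected range from 45000 nM to 220000 nM.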

Compound 3, half-maximal inhibitory concentration: 147000 nM
Beside the measured number, compound 3's estimate is 1.5-fold (0.17 log units) below it; the measured number falls inside the stated range.
By their numbers in this assay, from the lowest: compounds 2, 3 and 1 (each within the scatter of the next).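

In this assay, the exchange on the aromatic carbon para to a large group now has a measured step: methyl in place of bromo gives a 1.8-fold higher number from compound 2 to compound 3 (0.26 log units; within the scatter) and leaves the number at one level. Methoxy in place of hydrogen on an aromatic carbon gives a 1.1-fold lower number from compound 1 to compound 3 (0.03 log units; within the scatter) and also leaves the number at one level. No evidence bears on either step.

Going by these compounds, what an amine or a carboxylic acid on this aromatic carbon would give remains open. On these data alone, the effect of a longer chain in place of methyl also remains open.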